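This account rests on a few compounds, and the source may have more. Where it says the series, first, only, none or still open, it means among the compounds named here.

Compound 1, `COc1ccc(S(=O)(=O)N(CCn2cc(CNS(=O)(=O)c3ccc(F)cc3)nn2)[C@@H](C(=O)NO)C(C)C)cc1`, was tested in an assay on isolated protein for inhibition of matrix metalloproteinase-9 (Homo sapiens), read by fluorescence, with a stated time of 30 min (on this read-out lower numbers stand for stronger inhibition and higher numbers for weaker inhibition), where compound 1 gives 0.6 nM. Compound 2, `COc1ccc(S(=O)(=O)N(CCn2cc(CN(C)S(=O)(=O)c3ccc(F)cc3)nn2)[C@@H](C(=O)NO)C(C)C)cc1`, carries methyl in place of hydrogen on a sulfonamide nitrogen on the same core; in this assay compound 2 gives 3 nM, a step of a 5.0-fold higher number from compound 1 to compound 2 (0.70 log units; beyond the scatter). Compound 3, `CC(C)[C@H](C(=O)NO)N(CCn1cc(CNS(=O)(=O)c2ccc(F)cc2)nn1)S(=O)(=O)c1ccc(OCCF)cc1`, differs from compound 1 by fluoromethyl in place of hydrogen on a saturated chain carbon bound to an oxygen on an aromatic ring, and this is also the whole difference between the core of compound 1 and the core of compound 3. In this assay compound 3 gives 3 nM, which amounts to a 5.0-fold higher number from compound 1 to compound 3 (0.70 log units; beyond the scatter). Compound 3 and compound 2 stand level at the digits reported, and together they sit furthest from compound 1.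

Compound 4, `CC(C)[C@H](C(=O)NO)N(CCn1cc(CN(C)S(=O)(=O)c2ccc(F)cc2)nn1)S(=O)(=O)c1ccc(OCCF)cc1`, has not yet been measured. It differs from compound 3 by methyl in place of hydrogen on a sulfonamide nitrogen. Among the measured compounds shown here, this is the same change as the one from compound 1 to compound 2, now made on the core of compound 3, and the surroundings of the altered nitrogen are the same in both cases.

Compound 4 is expected to move from compound 3 by a 5.0-fold higher number from compound 3 to compound 4 (0.70 log units; beyond the scatter) in this assay, because a 5.0-fold higher number from compound 1 to compound 2 (0.70 log units; beyond the scatter) was seen for the same change on the other core. This expectation rests on a single earlier instance of the change, so some widening of the range is warranted. The estimate for compound 4 in this assay is 15 nM, expected to fall between 5 nM and 45 nM.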

Compound 4, half-maximal inhibitory concentration: 11 nM
Compound 4: middle estimate off by 1.4-fold (0.13 log units), on the high side, and the stated range covers the measured number.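

In this assay, among the compounds shown here, methyl in place of hydrogen on a sulfonamide nitrogen gives a 3.7-fold higher number from compound 3 to compound 4 (0.56 log units; beyond the scatter), and this step agrees with the one seen for the same change on the core of compound 1: the same change on two cores in this assay, a 5.0-fold higher number (0.70 log units; beyond the scatter) from compound 1 to compound 2 and a 3.7-fold higher number (0.56 log units; beyond the scatter) from compound 3 to compound 4, 1.4-fold (0.13 log units) apart, within the scatter of two such steps The other change, fluoromethyl in place of hydrogen on a saturated chain carbon bound to an oxygen on an aromatic ring, gives a 3.7-fold higher number from compound 2 to compound 4 (0.56 log units; beyond the scatter), and it also agrees with its earlier step: the same change on two cores in this assay, a 5.0-fold higher number (0.70 log units; beyond the scatter) from compound 1 to compound 3 and a 3.7-fold higher number (0.56 log units; beyond the scatter) from compound 2 to compound 4, 1.4-fold (0.13 log units) apart, within the scatter of two such steps Across these four compounds, each change therefore carried over from one core to the other with its size preserved within the scatter, but this rests on only two cores in a single assay and does not show that either step would hold on other cores or explain why the steps have this size.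

The compounds shown leave open how a longer chain or an amine on that sulfonamide nitrogen would read in this assay, since methyl is the only group there apart from hydrogen. They also leave open whether a longer fluoroalkyl chain on the aromatic oxygen would give a step of similar size on either core.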